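Fixing the ring stereocentre in a glycine transporter inhibitor

This account rests on a few compounds, and the source may have more. Where it says the series, first, only, none or still open, it means among the compounds named here.

Compound 1 `COc1ccc(Sc2ccc(Cl)cc2N2CCN(CC(=O)O)C(C)C2)cc1` is tested in an assay for inhibition of sodium- and chloride-dependent glycine transporter 1 (Homo sapiens) (a lower number here means a stronger inhibitor, a higher number a weaker inhibitor), where compound 1 gives 290 nM, the lowest of the two numbers seen so far. Within the data shown here, its only measured neighbour is compound 2 `COc1ccc(Sc2ccc(OC)cc2N2CCN(CC(=O)O)C(C)C2)cc1`, which in this assay gives 4600 nM; that is a 16-fold higher number from compound 1 to compound 2 (1.20 log units; beyond the scatter), a change that comes with a methoxy in place of chloro on an aromatic carbon. Compound 3 `COc1ccc(Sc2ccc(Cl)cc2N2CCN(CC(=O)O)[C@H](C)C2)cc1` keeps every atom and bond of compound 1 and differs only in that (the two compounds have the same atoms and bonds; at least one stereo element is drawn with a configuration in one of them and without one in the other: 1 of 1 stereo elements differ; a stereocentre at a saturated ring carbon is drawn without a configuration in compound 1 and R in compound 3). Among the measured compounds shown here, the one measured step, from compound 1 to compound 2, concerns a group swap rather than stereochemistry, so it gives no guidance here, and the data hold no other pair that separates the two configurations. The expected step is therefore a 1.0-fold higher number from compound 1 to compound 3 (0.01 log units; within the scatter), with wide uncertainty in either direction. Compound 3 is estimated at 300 nM, within a range from 100 nM to 2000 nM.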

Compound 3, half-maximal inhibitory concentration: 150 nM
The estimate for compound 3 lay 2.0-fold (0.30 log units) above the measured number, within the range that was stated.
By their numbers in this assay, from the lowest: compounds 3 and 1 (each within the scatter of the next); then compound 2.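

In this assay, defining the stereocentre at the saturated ring carbon as R gives a 1.9-fold lower number from compound 1 to compound 3 (0.29 log units; within the scatter). Among these compounds, this is the first information about this position, since the earlier step from chloro to methoxy left the configuration untouched. The R form therefore stays within the scatter of the compound drawn without a configuration, and this comparison carries a caution, as it does not set one defined configuration against the other; what separates the pair is only: the fact that one of compounds 1 and 3 is drawn with a defined configuration and the other without, at the place where they differ

From the compounds shown here alone, how the S configuration compares with the R configuration remains open, so the importance of this stereocentre cannot yet be judged. Also open, going by these compounds, is how an ethyl group in place of the methyl at this ring carbon would fare in this assay.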